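The source may hold more compounds than are shown below. What is called first, only, known or untested is meant among the compounds shown, and "the series" means these compounds.

Measured so far in a functional assay on KM12 cells (Homo sapiens) for inhibition, read by sulforhodamine B assay, with a stated time of 48 h; a higher number here means a weaker inhibitor of growth, a lower number a stronger inhibitor of growth:
compound 1, `COc1cc2cc(Oc3ccc(NC(=O)Nc4cccc(C(F)(F)F)c4)cc3)c(C)nc2cc1OC`: 1420 nM
compound 2, `COc1cc2cc(Oc3ccc(NC(=O)Nc4ccc(Cl)c(C(F)(F)F)c4)cc3)c(C)nc2cc1OC`: 1070 nM

Compound 2 gives the lowest of the two numbers, though its nearest neighbour compound 1 lies within the scatter of it (a 1.3-fold lower number from compound 1 to compound 2 (0.12 log units; within the scatter)). Compound 3, `COc1cc2cc(Oc3ccc(NC(=O)Nc4ccc(Cl)c(Cl)c4)cc3)c(C)nc2cc1OC`, differs from compound 2 by chloro in place of trifluoromethyl on an aromatic carbon. For the measured compounds named here, the single measured step, a 1.3-fold lower number from compound 1 to compound 2 (0.12 log units; within the scatter), concerns a different change and was small; no step in this assay shows a trifluoromethyl replaced by a chloro. A step no larger than the scatter is therefore expected, in no fixed direction. Compound 3 is estimated at 1100 nM, range 400 nM to 3000 nM, which amounts to an expected step of a 1.0-fold higher number from compound 2 to compound 3 (0.01 log units; within the scatter).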

Compound 3, concentration for 50% growth inhibition: 3220 nM
The estimate for compound 3 lay 2.9-fold (0.47 log units) below the measured number, outside the stated range (above it).
By their numbers in this assay, from the lowest: compounds 2 and 1 (each within the scatter of the next); then compound 3.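

In this assay, for the compounds shown here, this is the first single change to move the number beyond the scatter: on the aromatic carbon ortho to a chloro group, chloro in place of trifluoromethyl gives a 3.0-fold higher number from compound 2 to compound 3 (0.48 log units; beyond the scatter). Swapping 3-(trifluoromethyl)phenyl for 3,4-dichlorophenyl also gives a 2.3-fold higher number from compound 1 to compound 3 (0.36 log units; beyond the scatter), so at this position trifluoromethyl is the better of the two groups shown. Nothing available explains this rise.

Still open, from the compounds shown here alone, is whether a nitrile, methoxy or amine at this position would match trifluoromethyl. Also open, going by these compounds, is whether the step from trifluoromethyl to chloro keeps its size without the neighbouring chloro group.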